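From oxan-4-yl to oxolan-3-yl on compound 3

This account rests on a few compounds, and the source may have more. Where it says the series, first, only, none or still open, it means among the compounds named here.

Among the measured compounds shown here, in a physicochemical assay for solubility, read by mass spectrometry, in phosphate buffer, with a stated time of 24 h, at pH 7.4 (a higher number here means a more soluble compound, a lower number a less soluble compound), compound 3 `O=C(Nc1ccc(C(F)(F)F)c(F)c1)NC1CCN(C(=O)C2CCOCC2)CC1` gives 42 ug/mL, the highest of the three numbers measured so far. Compound 2 `CC(C)C(=O)N1CCC(NC(=O)Nc2ccc(C(F)(F)F)c(F)c2)CC1` gives 5.9 ug/mL, and compound 1 `O=C(Nc1ccc(C(F)(F)F)cc1)NC1CCN(C(=O)[C@@H]2CCOC2)CC1` gives 1.4 ug/mL. Compound 4 `O=C(Nc1ccc(C(F)(F)F)c(F)c1)NC1CCN(C(=O)[C@@H]2CCOC2)CC1` has not yet been measured. It keeps the core of compound 3 and changes a single group: oxolan-3-yl in place of oxan-4-yl on a carbonyl carbon. In words, oxolan-3-yl stands in place of oxan-4-yl on a carbonyl carbon.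

For the measured compounds named here, only one measured step touches this place: a 7.1-fold higher number from compound 2 to compound 3 (0.85 log units; beyond the scatter), a modest step beyond the scatter, with oxan-4-yl in place of isopropyl on a carbonyl carbon. It shows that the number can move with the group at this place, but it says nothing directly about oxolan-3-yl. Going by the values given here, compound 1 also carries oxolan-3-yl on that carbonyl carbon and stands at 1.4 ug/mL, although no measured step isolates that group. With compound 1 that low, a modest step down is expected in this assay, rather than a rise. The expected change is a 2.8-fold lower number from compound 3 to compound 4 (0.45 log units; beyond the scatter). For compound 4 the estimated solubility is 15 ug/mL, with an expected range from 4 ug/mL to 50 ug/mL.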

Compound 4, solubility: 1.9 ug/mL
For compound 4 the middle estimate is 7.9-fold (0.90 log units) above the measured one; the whole stated range lies above it.
By their numbers in this assay, from the lowest: compounds 1 and 4 (each within the scatter of the next); then compound 2; then compound 3.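

In this assay, the change from oxan-4-yl to oxolan-3-yl on a carbonyl carbon is a large step down, a 22-fold lower number from compound 3 to compound 4 (1.34 log units; beyond the scatter), so two groups that each hold one non-aromatic ring and one hydrogen-bond acceptor, with a difference of a single heavy atom, are far apart at this position. Oxolan-3-yl also stands under isopropyl at the same place, a 3.1-fold lower number from compound 2 to compound 4 (0.49 log units; beyond the scatter), which puts the three groups measured on this core in the order oxan-4-yl, isopropyl, oxolan-3-yl and shows that the earlier step, a 7.1-fold higher number from compound 2 to compound 3 (0.85 log units; beyond the scatter), was not the whole range of this position. With oxolan-3-yl held fixed, fluoro in place of hydrogen on an aromatic carbon gives a 1.4-fold higher number from compound 1 to compound 4 (0.13 log units; within the scatter), a step within the scatter, so that change shows no readable effect in this pair.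

Nothing given here accounts for the large gap between the two ring groups. Still open, from the compounds shown here alone, are how oxolan-3-yl with the opposite stereocentre would read at this place, how a group carrying an amine or a carboxylic acid would compare, and whether fluoro in place of hydrogen would also leave the number unchanged with oxan-4-yl on the carbonyl carbon.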